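A few compounds are considered here, and "the series" means these few. Any claim that something is new, unique, unknown or untested is made for them only; others in the source may bear on it.

Measured compounds in the series:
compound 1, `COc1ccccc1/C=C1\CCC/C(=C\c2cccc(OC)c2OC)C1=O` — 14100 nM
compound 2, `COc1cccc(/C=C2\CCC/C(=C\c3cccc(OC)c3OC)C2=O)c1` — 9900 nM
compound 3, `COc1ccccc1/C=C1\CCC/C(=C\c2ccc(OC)c(OC)c2)C1=O` — 8100 nM

All three were run in a functional assay on HT-1080 cells (Homo sapiens) for cytotoxicity, read by MTT assay, with a stated time of 72 h; on this read-out higher numbers stand for weaker inhibition and lower numbers for stronger inhibition. In this assay compound 1 gives 14100 nM and compound 2 gives 9900 nM. The two differ by 3-methoxyphenyl in place of 2-methoxyphenyl on a double-bonded chain carbon bound to a double-bonded ring carbon. This change made the step of a 1.4-fold lower number from compound 1 to compound 2 (0.15 log units; within the scatter), so the two values cannot be told apart. Compound 3 gives 8100 nM in this assay; its value lies within the scatter of both compound 1 and compound 2. How the core of compound 3 differs from the core of compound 1 is not broken down here.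

Compound 4, `COc1cccc(/C=C2\CCC/C(=C\c3ccc(OC)c(OC)c3)C2=O)c1`, is the compound still to be measured. It differs from compound 3 by 3-methoxyphenyl in place of 2-methoxyphenyl on a double-bonded chain carbon bound to a double-bonded ring carbon, the same change as between compound 1 and compound 2, at the same place. For the measured compounds named here, the step from compound 3 to compound 4 is therefore expected to be a 1.4-fold lower number from compound 3 to compound 4 (0.15 log units; within the scatter), a size that rests on the one earlier instance of this change, a 1.4-fold lower number from compound 1 to compound 2 (0.15 log units; within the scatter), which stayed within the scatter. Compound 4 is accordingly estimated at 5800 nM in this assay, with an expected range from 3000 nM to 11000 nM.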

Compound 4, half-maximal inhibitory concentration: 4600 nM
For compound 4 the middle estimate is 1.3-fold (0.10 log units) above the measured one, and the stated range covers the measured number.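

In this assay, 3-methoxyphenyl in place of 2-methoxyphenyl on a double-bonded chain carbon bound to a double-bonded ring carbon gives a 1.8-fold lower number from compound 3 to compound 4 (0.25 log units; within the scatter). Set beside the earlier instance of this change, the step shows no detectable dependence on the core: the same change on two cores in this assay, a 1.4-fold lower number (0.15 log units; within the scatter) from compound 1 to compound 2 and a 1.8-fold lower number (0.25 log units; within the scatter) from compound 3 to compound 4, 1.2-fold (0.09 log units) apart, within the scatter of two such steps The two steps show only that the change stays within the scatter on both cores, so neither can be read as a real shift in cytotoxicity, and two cores cannot show whether the change would stay this small on any other core in the series.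

Every aromatic ring in the compounds shown carries only methoxy groups, so it remains open how the values would respond to a hydroxyl group, a fluorine atom or an amine on those rings. Also open, on these data alone, is whether a carboxylic acid or a longer chain in place of a methoxy group would move the numbers beyond the scatter.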